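Benzylsulfanyl variation in a series of compounds with low inhibition numbers

This account rests on a few compounds, and the source may have more. Where it says the series, first, only, none or still open, it means among the compounds named here.

Measured compounds and values:
compound 1 `COc1ccc(C2N=C(SCc3ccc(F)cc3)NC(C)=C2C(=O)Nc2ccc(F)cc2)cc1OC` — 15.5%
compound 2 `CC1=C(C(=O)Nc2ccc([N+](=O)[O-])cc2)C(c2ccc(Br)cc2)N=C(SCc2ccccc2Cl)N1` — 7.7%

In a functional assay on the whole organism (artery, strain albino) with Rattus norvegicus as the target, with a stated time of 120 min, at a dose of 10 mg/kg by the oral route (on this read-out lower numbers stand for less inhibition and higher numbers for more inhibition at the one dose given (going by the name of the read-out)), compound 1 gives 15.5% and compound 2 gives 7.7%. On the numbers alone compound 2 sits at the low end of the pair, but its distance from compound 1 is within the scatter, so the two cannot be told apart in this assay. Both read-outs are small, and nothing in the pair points to a structural feature that raises or lowers the number.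

Compound 3 `CC1=C(C(=O)Nc2ccc([N+](=O)[O-])cc2)C(c2ccc(Br)cc2)N=C(SCc2ccc(F)cc2)N1` has not yet been measured. Its relation to compound 2 is a single change: 4-fluorophenyl in place of 2-chlorophenyl on a saturated chain carbon bound to a sulfur. The rest of the structure, including the nitro-substituted anilide and the bromophenyl group, is carried over unchanged.

Going by the values given here, no measured step of this kind exists, so there is no measured basis for a direction. Given that both measured values are low and close to each other, the expected step from compound 2 to compound 3 is a number 2.3 percentage points higher from compound 2 to compound 3 (within the scatter), that is, none beyond the scatter. Compound 3 is therefore estimated at 10% in this assay, with a range from 0% to 25%.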

Compound 3, a percentage reported as inhibition, in the whole organism at one dose (the size of the read-out at that dose, not a potency): 12.9%
Beside the measured number, compound 3's estimate is 2.9 percentage points below it; the range from low to high includes it.
By their numbers in this assay, from the lowest: compounds 2, 3 and 1 (each within the scatter of the next).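

In this assay, going by these compounds alone, 4-fluorophenyl in place of 2-chlorophenyl on a saturated chain carbon bound to a sulfur gives a number 5.2 percentage points higher from compound 2 to compound 3 (within the scatter), the only step read with the rest of the structure held constant. With the nitro-substituted anilide and the bromophenyl group carried over, this exchange of one halogen-bearing phenyl ring for another therefore leaves compound 2 and compound 3 indistinguishable, which the pair of compound 1 and compound 2, differing in several places, could not show. No supporting data bear on why the read-out stays within the scatter here.

Within the data shown here, the single step swaps the halogen and its place on the ring together, so the contributions of 2-chlorophenyl and 4-fluorophenyl cannot be separated, and a 4-chlorophenyl or 2-fluorophenyl group would be needed to pull them apart. Also open, going by these compounds, is whether a group of another kind on the sulfur, such as a plain ethyl chain, a chain ending in a carboxylic acid or one ending in a dimethylamino group, would shift the number beyond the scatter.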